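Swapping a Methoxyphenyl for a Difluorophenyl on the Amide

The compounds below may be only part of what the source reports. "The series", "measured", "known", "first", "only" and "open" are said of these compounds alone.

Compound 1 `Cc1ccc(C(=O)Nc2cccc(-c3oc4cc(-c5ccc(F)cc5)ccc4c(=O)c3O)c2)cc1`: 6190 nM
Compound 2 `COc1cccc(C(=O)Nc2cccc(-c3oc4cc(-c5ccc(F)cc5)ccc4c(=O)c3O)c2)c1`: 5650 nM

In a functional assay on HeLa cells (Homo sapiens) for antiproliferative activity, read by CCK-8 assay, with a stated time of 72 h (a higher number here means a weaker inhibitor, a lower number a stronger inhibitor), compound 2 holds the lowest of the two numbers, yet the step of a 1.1-fold lower number from compound 1 to compound 2 (0.04 log units; within the scatter) lies within the scatter, so the two compounds are not told apart. Compound 3 `O=C(Nc1cccc(-c2oc3cc(-c4ccc(F)cc4)ccc3c(=O)c2O)c1)c1cc(F)cc(F)c1` differs from compound 2 in one place: 3,5-difluorophenyl in place of 3-methoxyphenyl on a carbonyl carbon. Within the data shown here, the only measured step, a 1.1-fold lower number from compound 1 to compound 2 (0.04 log units; within the scatter), also exchanged one substituted phenyl for another on the carbonyl carbon and moved nothing beyond the scatter. Among the measured compounds shown here, no measured step introduces fluorine on that ring. The step of a 1.0-fold lower number from compound 2 to compound 3 (0.01 log units; within the scatter) is therefore expected to stay within the scatter. Compound 3 is estimated at 5500 nM, between 2500 nM and 12000 nM.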

Compound 3, half-maximal inhibitory concentration: 3380 nM
Estimate against measurement, compound 3: 1.6-fold (0.21 log units) above, and the stated range covers the measured number.
By their numbers in this assay, from the lowest: compounds 3, 2 and 1 (each within the scatter of the next).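

Fluorine on this ring does not separate the compounds in this assay: replacing 3-methoxyphenyl with 3,5-difluorophenyl gives a 1.7-fold lower number from compound 2 to compound 3 (0.22 log units; within the scatter) and replacing 4-methylphenyl gives a 1.8-fold lower number from compound 1 to compound 3 (0.26 log units; within the scatter) as well. The hydrogen-bond acceptor count of the group falls from 1 to 0 in the first of these changes, yet this step too stays within the scatter. No available evidence offers a reason for these numbers.

Open, as far as these compounds go, is whether an amine or a carboxylic acid on this ring, or a longer chain in place of the ring, would move the number beyond the scatter.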